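The compounds below may be only part of what the source reports. "The series", "measured", "known", "first", "only" and "open" are said of these compounds alone.

Working notes on the series. Compound 1 `CCCCCSc1nc(Nc2ccc(SC)cc2)c2cn[nH]c2n1` and compound 2 `CCCCCSc1nc(OC(=O)c2ccccc2)c2cn[nH]c2n1` share one core, differing at the substituent on it. In a functional assay on MCF7 cells (Homo sapiens) for antiproliferative activity, read by fluorescence, with a stated time of 3 days (on this read-out lower numbers stand for stronger inhibition and higher numbers for weaker inhibition), compound 1 gives 19200 nM; in this assay compound 2 gives 18900 nM, a number within the scatter of that of compound 1, so the two stand together. Compound 3 `CCCCCSc1nc(OC(=O)c2cc3ccccc3o2)c2cn[nH]c2n1` is not yet measured. It differs from compound 2 by 1-benzofuran-2-yl in place of phenyl on a carbonyl carbon. For the measured compounds named here, no measured step of this kind exists, so nothing beyond the scatter is expected in either direction. The step from compound 2 to compound 3 is estimated at a 1.3-fold lower number from compound 2 to compound 3 (0.10 log units; within the scatter), and compound 3 is expected to give 15000 nM, with a range of 5000 nM to 45000 nM in this assay.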

Compound 3, half-maximal inhibitory concentration: 18900 nM
The estimate for compound 3 lay 1.3-fold (0.10 log units) below the measured number; the measured number falls inside the stated range.
By their numbers in this assay, from the lowest: compounds 2, 3 and 1 (each within the scatter of the next).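

For the compounds shown here, the first measured step at this position gives no change at the digits printed from compound 2 to compound 3 (within the scatter) in this assay, so 1-benzofuran-2-yl, with its added five-membered aromatic ring and hydrogen-bond acceptor, leaves the number where phenyl had it. Within this single pair, the enlarged aromatic group on the carbonyl carbon brings no shift beyond the scatter. Nothing at hand bears on the reason for this result. Still open, as far as these compounds go, is whether an amine or a carboxylic acid on the carbonyl carbon, in place of the aromatic groups, would move the number beyond the scatter.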